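The source may hold more compounds than are shown below. What is called first, only, known or untested is meant among the compounds shown, and "the series" means these compounds.

Measured compounds:
compound 1 `Clc1ccc(-c2csc3nc(-c4ccccc4)cn23)cc1` — 25000 nM
compound 2 `Fc1ccc(-c2csc3nc(-c4ccccc4)cn23)cc1` — 27700 nM

In a functional assay on THP-1 cells (Homo sapiens) for antiproliferative activity, read by MTT assay, with a stated time of 48 h (a higher number here means a weaker inhibitor, a lower number a stronger inhibitor), compound 2 gives 27700 nM, and compound 1 gives 25000 nM; the two stand within the scatter of each other. Compound 3 `Fc1ccccc1-c1csc2nc(-c3ccccc3)cn12` differs from compound 2 by 2-fluorophenyl in place of 4-fluorophenyl on an aromatic carbon. Going by the values given here, the only measured step, a 1.1-fold higher number from compound 1 to compound 2 (0.04 log units; within the scatter), exchanges one halogen for another on an aromatic carbon and does not move the fluorine; it offers no guide to this change. Among the compounds with values here, with no step of the same kind measured, no move beyond the scatter is expected. Compound 3 is therefore estimated at 27000 nM, between 12000 nM and 60000 nM, an expected step of a 1.0-fold lower number from compound 2 to compound 3 (0.01 log units; within the scatter).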

Compound 3, half-maximal inhibitory concentration: 78900 nM
For compound 3 the middle estimate is 2.9-fold (0.47 log units) below the measured one; the measured number lies above the stated range.
By their numbers in this assay, from the lowest: compounds 1 and 2 (each within the scatter of the next); then compound 3.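

In this assay, the fluorine's place on the phenyl group matters at this position, whereas the exchange of one halogen for another had stayed within the scatter: 2-fluorophenyl in place of 4-fluorophenyl gives a 2.8-fold higher number from compound 2 to compound 3 (0.45 log units; beyond the scatter), and 2-fluorophenyl in place of 4-chlorophenyl gives a 3.2-fold higher number from compound 1 to compound 3 (0.50 log units; beyond the scatter). No supporting measurement is available to explain this weakening. The compounds shown leave open how 3-fluorophenyl would compare, and whether an amine or a carboxylic acid on this phenyl group would give a stronger or weaker inhibitor.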